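Moving one chlorine on a dichlorophenyl sulfone

The source may hold more compounds than are shown below. What is called first, only, known or untested is meant among the compounds shown, and "the series" means these compounds.

Growth values in a functional assay on SW-620 cells (Homo sapiens); a higher number here means a weaker inhibitor of growth, a lower number a stronger inhibitor of growth:
- compound 1 `O=S(=O)(/C=C/c1ccc(Cl)c(Cl)c1)Cc1ccc(Nc2ncnc3ccccc23)cc1` gives 41000 nM
- compound 2 `CC(C)(C)c1cc(/C=C/S(=O)(=O)Cc2ccc(Nc3ncnc4ccccc34)cc2)cc(C(C)(C)C)c1O` gives 9000 nM
- compound 3 `O=S(=O)(/C=C/c1ccc(Cl)c(Cl)c1)Cc1ccc(Nc2ncnc3ccc(Br)cc23)cc1` gives 5000 nM

Compound 3 lies within the scatter of compound 2 and well under compound 1 in this assay. Compound 4 `O=S(=O)(/C=C/c1ccc(Cl)cc1Cl)Cc1ccc(Nc2ncnc3ccc(Br)cc23)cc1` is the next to be tested, and it differs from compound 3 as follows: 2,4-dichlorophenyl in place of 3,4-dichlorophenyl on a double-bonded chain carbon bound to a double-bonded chain carbon. Among the measured compounds shown here, the one measured step, an 8.2-fold lower number from compound 1 to compound 3 (0.91 log units; beyond the scatter), places bromo in position of hydrogen, so it does not bear on this chlorine change. For the measured compounds named here, no measured step moves a chlorine, so no shift beyond the scatter is expected. The expected step is a 1.1-fold higher number from compound 3 to compound 4 (0.04 log units; within the scatter). For compound 4 the estimated value is 5500 nM, with an expected range of 2000 nM to 15000 nM.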

Compound 4, concentration for 50% growth inhibition: > 100000 nM
Compound 4 was reported as a limit; the forecaster's own chance of this, stated with the estimate: 5%; middle value at least 18-fold (1.25 log units) away from the limit.
By their numbers in this assay, from the lowest: compounds 3 and 2 (each within the scatter of the next); then compound 1. At a limit, above all of these: compound 4.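

On the double-bonded chain carbon, the placement of the chlorines matters in this assay: with the same atoms joined differently, 2,4-dichlorophenyl in place of 3,4-dichlorophenyl gives an at least 20-fold higher number from compound 3 to compound 4 (1.30 log units; beyond the scatter). Among the compounds shown here, the only earlier step changed hydrogen to bromo, so this is the first sign that rearranging the ring substituents alone can produce a large shift. Compound 4 is reported only as a limit: the limit of > 100000 nM in this assay, at which 1 of the 4 values shown sits.

As far as these compounds go, whether 2,4-dichlorophenyl has the same effect on the core of compound 1, without the bromo, stays open. So does the outcome with a methoxy group or an amine on this ring.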